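The compounds below may be only part of what the source reports. "The series", "measured", "known", "first", "only" and "open" are said of these compounds alone.

For the measured compounds named here, compound 1 `CCOC(=O)CCO/N=C(/c1ccc(OC)c(OC)c1OC)c1cccc2ccccc12` is the one member of this small set that returns a number. In a functional assay on HCT-116 cells (Homo sapiens) for inhibition, read by sulforhodamine B assay, with a stated time of 48 h (on this read-out lower numbers stand for stronger inhibition and higher numbers for weaker inhibition), compound 1 gives 10000 nM. Compound 2 `COc1cc(COC(c2ccc(OC)c(OC)c2OC)c2cccc3ccccc23)cc(OC)c1` gives only a limit of the assay in this assay, > 20000 nM. Compound 3 `COc1ccc(C(OCc2ccccc2)c2cccc3ccccc23)c(OC)c1OC` likewise gives only a limit in this assay, > 20000 nM. Going by the values given here, the one change that can be traced between measured compounds, phenyl in place of 3,5-dimethoxyphenyl on a saturated chain carbon bound to an oxygen on a saturated carbon, is a step that the two limits leave unreadable from compound 2 to compound 3, so it says nothing about how large a change of that kind is. Compound 1 therefore stands as the only number shown, while two of the three values sit at the limit of > 20000 nM in this assay, at which 2 of the 3 values shown sit.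

Compound 4 `CCOC(=O)CO/N=C(/c1ccc(OC)c(OC)c1OC)c1cccc2ccccc12` differs from compound 1 in one place: ethoxycarbonyl in place of (ethoxycarbonyl)methyl on a saturated chain carbon bound to an oxygen on an unsaturated carbon. Cut one bond further out, the same difference reads 2-(ethoxycarbonyl)ethyl to (ethoxycarbonyl)methyl, or 2-(ethoxycarbonyl)ethoxy to (ethoxycarbonyl)methoxy. Among the compounds with values here, no measured step concerns this kind of change, and the single measured step is unreadable, so nothing in the data points to a shift beyond the usual scatter in either direction. The expected step from compound 1 to compound 4 is therefore no change at the digits printed from compound 1 to compound 4 (within the scatter). Compound 4 is estimated at 10000 nM, within a range of 4000 nM to 25000 nM.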

Compound 4, half-maximal inhibitory concentration: 3360 nM
Compound 4: the middle estimate sits 3.0-fold (0.47 log units) above what was measured; measured number outside the range, below it.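

Replacing 2-(ethoxycarbonyl)ethyl with (ethoxycarbonyl)methyl gives a 3.0-fold lower number from compound 1 to compound 4 (0.47 log units; beyond the scatter) in this assay, and this is the first step among the compounds shown whose size can be read. It shows that the number responds to a small edit at this place, on a saturated chain carbon bound to an oxygen on an unsaturated carbon: the two groups have the same hydrogen-bond donor and acceptor counts and neither carries a ring, yet the shorter one gives a lower number, meaning stronger inhibition. Nothing measured here says why the number moves.

On these data alone, this single pair gives one direction over one change, so it remains open whether the number would keep its course or turn with a chain of another length, such as a longer chain than the 2-(ethoxycarbonyl)ethyl group of compound 1. It also leaves open what a carboxylic acid or a primary amide in place of the ethyl ester, or an amine at the end of the same chain, would do in this assay.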